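Moving the nitrile from the 3- to the 4-position of the anilino ring

A few compounds are considered here, and "the series" means these few. Any claim that something is new, unique, unknown or untested is made for them only; others in the source may bear on it.

Measured compounds:
- compound 1, `COc1ccc2c(c1)NC(=O)CN2c1nc(OCC2CC2)nc2ccccc12`: 7.88 nM
- compound 2, `COc1ccc2c(c1)NC(=O)CN2c1nc(Nc2cccc(C#N)c2)nc2ccccc12`: 384 nM
- compound 3, `COc1ccc2c(c1)NC(=O)CN2c1nc(N2CCCC2)nc2ccccc12`: "not determined" (no result reported)

In a functional assay on MCF7 cells (Homo sapiens) for inhibition, read by sulforhodamine B assay, with a stated time of 48 h (on this read-out higher numbers stand for weaker inhibition of growth and lower numbers for stronger inhibition of growth), compound 1 gives 7.88 nM, while compound 2 gives 384 nM. Compound 3 carries a pyrrolidine on the same carbon, but in this assay compound 3 has only the entry "not determined" (no result reported) and no number. Among the two measured numbers, compound 2 stands highest; the only step on record is a 49-fold higher number from compound 1 to compound 2 (1.69 log units; beyond the scatter), which places the (3-cyanophenyl)amino compound well beyond the scatter from its cyclopropylmethoxy partner.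

Compound 4, `COc1ccc2c(c1)NC(=O)CN2c1nc(Nc2ccc(C#N)cc2)nc2ccccc12`, differs from compound 2 only in the placement of the nitrile: 4-cyanophenyl in place of 3-cyanophenyl on a nitrogen on an aromatic ring. Among the measured compounds shown here, no measured step moves the nitrile around the ring, so the one recorded step says little about this change, and the two anilino compounds share the same atoms. The expectation for this assay is therefore a step of a 1.0-fold higher number from compound 2 to compound 4 (0.02 log units; within the scatter), not beyond the scatter. Compound 4 is estimated at 400 nM, within 120 nM to 1300 nM.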

Compound 4, concentration for 50% growth inhibition: 9.19 nM
Compound 4: the middle estimate sits 44-fold (1.64 log units) above what was measured; the whole stated range lies above it.
By their numbers in this assay, from the lowest: compounds 1 and 4 (each within the scatter of the next); then compound 2.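

In this assay the placement of the nitrile alone has a large effect: with the same atoms joined differently, the change gives a 42-fold lower number from compound 2 to compound 4 (1.62 log units; beyond the scatter). The (4-cyanophenyl)amino group also stands level with cyclopropylmethoxy on this aromatic carbon (a 1.2-fold higher number from compound 1 to compound 4 (0.07 log units; within the scatter)), so the high number of compound 2 does not hold for every (cyanophenyl)amino group and goes with the 3-cyanophenyl arrangement among the compounds shown. Nothing reported here gives a reason for the difference between the two nitrile placements.

As far as these compounds go, whether the result for compound 4 holds when a carboxylic acid or a primary amide replaces the nitrile on the 4-cyanophenyl ring remains open, as does how an unsubstituted phenyl on the same nitrogen compares. From the compounds shown here alone, compound 3 has no number, so how a pyrrolidine on this carbon compares also stays unknown.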